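The source may report more compounds than this note shows. Statements on the series, on what has been measured and on what is new or still open speak of the compounds shown alone.

Of the compounds shown here, three built on a shared core have been measured in a functional assay on MCF7 cells (Homo sapiens) for cytotoxicity, read by MTT assay, with a stated time of 24 h, tested at 80 ug/mL; on this read-out lower numbers stand for a weaker effect and higher numbers for a stronger effect at the one concentration tested. Compound 1 `Cn1nnnc1SCC(=O)Nc1ccc(-c2nc(-c3ccccc3)c(-c3ccccc3)n2C)cc1` gives 77.7% in this assay. Compound 2 `CCN1CCN(CC(=O)Nc2ccc(-c3nc(-c4ccccc4)c(-c4ccccc4)n3C)cc2)CC1` gives 46.3%, and the change from compound 1 to compound 2 produced a number 31.4 percentage points lower from compound 1 to compound 2 (beyond the scatter). Compound 3 `Cn1c(-c2ccc(NC(=O)CN3CCN(c4ccccc4)CC3)cc2)nc(-c2ccccc2)c1-c1ccccc1` gives 72.5%. Among the three numbers compound 3 stands second highest: its nearest neighbour is compound 1, with a number 5.2 percentage points lower from compound 1 to compound 3 (within the scatter), a gap within the scatter, while its furthest is compound 2, with a number 26.2 percentage points higher from compound 2 to compound 3 (beyond the scatter).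

Compound 4 `Cc1ccc(CN2CCN(CC(=O)Nc3ccc(-c4nc(-c5ccccc5)c(-c5ccccc5)n4C)cc3)CC2)cc1` differs from compound 3 in one place: 4-methylbenzyl in place of phenyl on an amine nitrogen in a ring. Within the data shown here, the only measured step on the same amine nitrogen in the ring is the one from compound 2 to compound 3, where phenyl replaced ethyl and gave a number 26.2 percentage points higher from compound 2 to compound 3 (beyond the scatter), a modest rise. Here the phenyl itself leaves and 4-methylbenzyl enters, which keeps an aromatic ring on that nitrogen but is otherwise untested, so no measured step tells directly how far the number will move.

The expectation for compound 4 is therefore a modest step downward, a number 8.5 percentage points lower from compound 3 to compound 4 (within the scatter), with wide uncertainty. Compound 4 is estimated at 64%, between 44% and 82%.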

Compound 4, a percentage reported as activity, at one concentration (the size of the read-out at that concentration, not a potency): 49.3%
The estimate for compound 4 lay 14.7 percentage points above the measured number, and the stated range covers the measured number.
By their numbers in this assay, from the lowest: compounds 2 and 4 (each within the scatter of the next); then compounds 3 and 1 (each within the scatter of the next).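

In this assay, 4-methylbenzyl in place of phenyl on the amine nitrogen in the ring gave a number 23.2 percentage points lower from compound 3 to compound 4 (beyond the scatter) and so showed that an aromatic ring on this nitrogen does not by itself keep the number where phenyl holds it, which the earlier rise from ethyl to phenyl could not show. Set against the ethyl group, the same 4-methylbenzyl group gave a number 3 percentage points higher from compound 2 to compound 4 (within the scatter) and thus no readable difference, so on this nitrogen compound 3 stands apart from both compound 2 and compound 4, while those two cannot be told apart. No measurement available here bears on what lies behind this drop.

The compounds shown leave open whether the difference between phenyl and 4-methylbenzyl goes with the added carbon link or with the methyl on the ring, a question that an unsubstituted benzyl and a 4-methylphenyl group on the same nitrogen would separate. From the compounds shown here alone, it also remains open whether a phenyl ring carrying a methoxy group or a chlorine would stay level with compound 3 or fall towards compound 2 and compound 4.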